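This account rests on a few compounds, and the source may have more. Where it says the series, first, only, none or still open, it means among the compounds named here.

Compound 1 `COc1ccc(-c2nc3cc(Cl)c(Cl)cc3[nH]2)cc1` and compound 2 `COc1ccc(-c2nc3cc(Cl)c(Cl)cc3[nH]2)c([N+](=O)[O-])c1` share a core and differ in one place; compound 3 `O=[N+]([O-])c1ccc(-c2nc3ccccc3[nH]2)c([N+](=O)[O-])c1` has a core whose difference from that of compound 2 is not broken down here. In an ADME assay on BHK cells (Mesocricetus auratus) for cytotoxicity, read by MTT assay, with a stated time of 96 h (a lower number here means that less compound is tolerated, a higher number that more compound is tolerated), compound 1 gives 18000 nM. In this assay compound 2 gives 80000 nM. For compound 3, this assay reports only a limit, > 100000 nM, which is the limit of > 100000 nM in this assay, at which 1 of the 3 values shown sits. The change hydrogen in place of nitro on an aromatic carbon made a 4.4-fold lower number from compound 2 to compound 1 (0.65 log units; beyond the scatter). Compound 4 `O=[N+]([O-])c1ccccc1-c1nc2ccccc2[nH]1` is not yet measured; it arises from compound 3 by the same kind of change, (hydrogen in place of nitro on an aromatic carbon), at a place that is meta to a nitro group and para to a group of 9 heavy atoms rather than ortho to a large group and meta to a methoxy group. Because of a 4.4-fold lower number from compound 2 to compound 1 (0.65 log units; beyond the scatter), a similar lowering is expected, an at least 2.5-fold lower number from compound 3 to compound 4 (0.39 log units; beyond the scatter), although the start is only a limit. Compound 4 is expected to give about 40000 nM, between 15000 nM and 100000 nM.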

Compound 4, half-maximal cytotoxic concentration: > 100000 nM
Compound 4: no number, only a limit (the forecaster's own chance of this, stated with the estimate: 25%); middle value at least 2.5-fold (0.39 log units) from the limit.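

Compound 3 and compound 4 each give only a limit, so no step between them can be read: the limit of > 100000 nM in this assay, at which 2 of the 4 values shown sit.

The compounds shown leave open whether hydrogen in place of nitro changes the number at all for this pair in this assay.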